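The source may hold more compounds than are shown below. What is called first, only, known or untested is meant among the compounds shown, and "the series" means these compounds.

Three compounds from one series have been run in an in vitro ADME assay on microsomes from liver (Simiiformes) (a lower number here means that the compound disappears faster, a higher number that the compound lasts longer), and a fourth awaits its number. Compound 1 `Cc1cc(CCCOc2c(C)cc(-c3noc(C)n3)cc2C)on1` gives 0.45 h. Compound 2 `CCc1cc(CCCOc2c(C)cc(-c3noc(C)n3)cc2C)on1` carries a longer chain on the five-membered ring at the far end: methyl in place of hydrogen on a saturated chain carbon bound to an aromatic carbon. In this assay compound 2 gives 0.183 h, so that a 2.5-fold lower number from compound 1 to compound 2 (0.39 log units; beyond the scatter). Compound 3 `COc1nc(-c2cc(C)c(OCCCc3cc(C)no3)c(C)c2)no1` differs from compound 1 in the other ring: methoxy in place of methyl on an aromatic carbon. In this assay compound 3 gives 0.55 h, and a 1.2-fold higher number from compound 1 to compound 3 (0.09 log units; within the scatter), so the two cores cannot be told apart on these data. Compound 4 `CCOc1nc(-c2cc(C)c(OCCCc3cc(C)no3)c(C)c2)no1` has not yet been measured. Compared with compound 3 the change is methyl in place of hydrogen on a saturated chain carbon bound to an oxygen on an aromatic ring. For the measured compounds named here, this is the same kind of change as the one from compound 1 to compound 2, a methyl added to a carbon that already bears one, but the place is not the same: there the carbon was bound to an aromatic carbon, here it is bound to an oxygen on an aromatic ring. Going by the values given here, with only one earlier example, the expectation rests on the step of a 2.5-fold lower number from compound 1 to compound 2 (0.39 log units; beyond the scatter) and on the starting point of compound 3 at 0.55 h. Compound 4 is therefore expected to show a shorter half-life than compound 3, with the step of a 2.2-fold lower number from compound 3 to compound 4 (0.34 log units; beyond the scatter) roughly matching the earlier one. Compound 4 is estimated at 0.25 h, most likely between 0.12 h and 0.5 h.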

Compound 4, half-life: > 2.5 h
Compound 4 was reported as a limit; the forecaster's own chance of this, stated with the estimate: 0%; middle value at least 10-fold (1.00 log units) from the limit.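

In this assay, going from methoxy to ethoxy gives an at least 4.5-fold higher number from compound 3 to compound 4 (0.65 log units; beyond the scatter), and going from methyl to ethoxy gives an at least 5.5-fold higher number from compound 1 to compound 4 (0.74 log units; beyond the scatter). Adding a methyl to a chain therefore has no single effect that can be carried from one core to the other in this series, since the earlier step and the new one run in opposite directions: the same change on two cores in this assay, a 2.5-fold lower number (0.39 log units; beyond the scatter) from compound 1 to compound 2 and an at least 4.5-fold higher number (0.65 log units; beyond the scatter) from compound 3 to compound 4, at least 11-fold (1.04 log units) apart, beyond the scatter of two such steps Compound 4 gives > 2.5 h, which is a limit of this assay and not a number, and one pair on each core, with the methyl added at a different place in each, shows neither why the two steps part nor how far apart they truly lie: the limit of > 2.5 h in this assay, at which 1 of the 4 values shown sits.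

The compounds shown leave open whether a longer chain, such as propoxy in place of ethoxy, would keep the compound in this assay for as long as the ethoxy group does. They also leave open whether the ethyl group on the far five-membered ring of compound 2 would lower the number on a core that carries the 5-ethoxy-1,2,4-oxadiazol-3-yl group.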